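A few compounds are considered here, and "the series" means these few. Any claim that something is new, unique, unknown or untested is made for them only; others in the source may bear on it.

Compound 1 `O=C1N/C(=N\Cc2ccccc2)S/C1=C1/CCNC(=O)c2[nH]ccc21`: 36500 nM
Compound 2 `COc1ccc(C/N=C2\NC(=O)/C(=C3\CCNC(=O)c4[nH]ccc43)S2)cc1`: 11500 nM
Compound 3 `O=C1N/C(=N\Cc2cccc(Cl)c2)S/C1=C1/CCNC(=O)c2[nH]ccc21`: 35300 nM

All three values come from a functional assay on HT-29 cells (Homo sapiens) for inhibition, read by MTT assay, with a stated time of 48 h; a higher number here means a weaker inhibitor, a lower number a stronger inhibitor. Compound 3 stands level with compound 1, as the comparison shows: a 1.0-fold lower number from compound 1 to compound 3 (0.01 log units; within the scatter). Compound 2 gives the lowest number of the three, and the comparison with compound 3 reads a 3.1-fold higher number from compound 2 to compound 3 (0.49 log units; beyond the scatter).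

The next compound, compound 4 `O=C1N/C(=N\Cc2ccccc2Cl)S/C1=C1/CCNC(=O)c2[nH]ccc21`, has 2-chlorophenyl in place of 3-chlorophenyl on a saturated chain carbon bound to a double-bonded nitrogen.

Among the measured compounds shown here, no measured pair shows this exact change, so the evidence is indirect. The closest guide is the addition of chloro to the unsubstituted compound 1, which gave a 1.0-fold lower number from compound 1 to compound 3 (0.01 log units; within the scatter). The methoxy change gave a larger, though still modest, result: a 3.2-fold lower number from compound 1 to compound 2 (0.50 log units; beyond the scatter). It involves a different group, so it bears less directly on compound 4, but it does show that changes on this aromatic ring can move the number in this assay. For the measured compounds named here, with only one chloro example, a shift in either direction cannot be ruled out.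

The expected result is a 1.2-fold lower number from compound 3 to compound 4 (0.07 log units; within the scatter), with no step beyond the scatter anticipated. Compound 4 is expected at an estimated 30000 nM, within an estimated range of 14000 nM to 60000 nM.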

Compound 4, half-maximal inhibitory concentration: > 100000 nM
Compound 4: no number, only a limit (the forecaster's own chance of this, stated with the estimate: 5%); middle value at least 3.3-fold (0.52 log units) from the limit.
By their numbers in this assay, from the lowest: compound 2; then compounds 3 and 1 (each within the scatter of the next). At a limit, above all of these: compound 4.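

Where the chloro sits on the ring matters here, which the earlier compounds could not show: with the same atoms joined differently, 2-chlorophenyl in place of 3-chlorophenyl gives an at least 2.8-fold higher number from compound 3 to compound 4 (0.45 log units; beyond the scatter). The earlier chloro step stayed within the scatter, so chloro in place of hydrogen does not leave the number level wherever it goes: this time it gives an at least 2.7-fold higher number from compound 1 to compound 4 (0.43 log units; beyond the scatter), and the gap from the 4-methoxyphenyl compound is wider still, an at least 8.6-fold higher number from compound 2 to compound 4 (0.93 log units; beyond the scatter). In this assay compound 4 reaches only a limit, so all of these steps are minimum sizes: the limit of > 100000 nM in this assay, at which 1 of the 4 values shown sits.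

The compounds shown leave open how far the true number of compound 4 lies past that limit, and whether this jump belongs to chloro alone or to any group placed as in 2-chlorophenyl. Fluoro, an amine or a carboxylic acid in that same place on the ring would help to separate these two readings.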